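A few compounds are considered here, and "the series" means these few. Any claim that something is new, unique, unknown or untested is made for them only; others in the source may bear on it.

Measured so far in an ADME assay on Vero cells (Chlorocebus sabaeus) for cytotoxicity, read by MTT assay, with a stated time of 72 h; on this read-out higher numbers stand for lower toxicity in this test and lower numbers for higher toxicity in this test:
compound 1 `COC(=O)c1cc(-c2cccc(NC(=O)c3ccc(/C=C/C(=O)c4ccc(Br)cc4)cc3)c2)on1`: > 20 ug/mL, a limit of the assay and not a number
compound 2 `COC(=O)c1cc(-c2cccc(NC(=O)c3ccc(/C=C/C(=O)c4ccc(C)c([N+](=O)[O-])c4)cc3)c2)on1`: > 80 ug/mL, a limit of the assay and not a number
compound 3 `COC(=O)c1cc(-c2cccc(NC(=O)c3ccc(/C=C/C(=O)c4ccccc4O)cc3)c2)on1`: "not determined" (no result reported)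

Compound 3 has no number in this assay; the two other values in the set are limits, recorded as the limit of > 20 ug/mL in this assay, at which 1 of the 3 values shown sits, and (the limit of > 80 ug/mL in this assay, at which 1 of the 3 values shown sits). For the measured compounds named here, the one step between measured compounds, a step that the two limits leave unreadable from compound 1 to compound 2, is therefore of unreadable size.

The next compound is compound 4 `COC(=O)c1cc(-c2cccc(NC(=O)c3ccc(/C=C/C(=O)c4ccccc4Br)cc3)c2)on1`. It differs from compound 3 in a single place: bromo in place of hydroxy on an aromatic carbon. Going by the values given here, no measured step bears on this change, and the only step in the set, a step that the two limits leave unreadable from compound 1 to compound 2, cannot be read. With compound 3 undetermined, there is no base value from which to project a direction or a size in this assay, and the two measured compounds both sit at limits. A readable step beyond the scatter is not expected; what is expected is that compound 4 again returns a value at or near a limit in this assay. Estimated for compound 4 in this assay: 40 ug/mL, within 10 ug/mL to 150 ug/mL.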

Compound 4, half-maximal cytotoxic concentration: > 40 ug/mL
Compound 4 was reported as a limit (the forecaster's own chance of this, stated with the estimate: 60%); the middle value sits exactly at the limit.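

In this assay compound 4 gives > 40 ug/mL, a limit of the assay and not a number. For the compounds shown here, compound 1, compound 2 and compound 4 all stand at limits, and no step among them can be read. Left open is where their half-maximal cytotoxic concentrations actually lie, and whether 2-bromophenyl and 2-hydroxyphenyl differ in this assay.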